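Series notes: 4-aminocyclohexyl replaced by methyl

The compounds below may be only part of what the source reports. "The series", "measured", "known", "first", "only" and "open" are said of these compounds alone.

Values in a functional assay on MDA-MB-435 cells (Homo sapiens) for cytotoxicity, read by MTT assay, with a stated time of 72 h; on this read-out lower numbers stand for stronger inhibition and higher numbers for weaker inhibition:
- compound 1 `NCCCNc1c(C(=O)NCc2ccc(F)cc2)nc(Br)c2cccnc12`: 5000 nM
- compound 2 `N[C@H]1CC[C@H](Nc2c(C(=O)NCc3ccc(F)cc3)nc(Br)c3cccnc23)CC1`: 6000 nM
- compound 3 `CNc1c(C(=O)NCc2ccc(F)cc2)nc(Br)c2cccnc12`: not yet measured

In this assay, among the compounds with values here, compound 2 stands level with compound 1, the only other measured compound, with a 1.2-fold higher number from compound 1 to compound 2 (0.08 log units; within the scatter). Compound 3 carries methyl in place of 4-aminocyclohexyl on a nitrogen on an aromatic ring. Within the data shown here, only one measured step bears on this change, and it is the same small step, a 1.2-fold higher number from compound 1 to compound 2 (0.08 log units; within the scatter). That step exchanged one amino-bearing group for another, whereas methyl carries no amino group, so it is a weak guide and the range must stay wide. A step within the scatter is expected, with no firm direction. The estimate amounts to a 1.1-fold lower number from compound 2 to compound 3 (0.04 log units; within the scatter). For compound 3 the expected value is 5500 nM, with an estimated range from 2000 nM to 15000 nM.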

Compound 3, half-maximal inhibitory concentration: > 20000 nM
Compound 3 gave a limit, no number (the forecaster's own chance of this, stated with the estimate: 15%); middle value at least 3.6-fold (0.56 log units) from the limit.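

In this assay compound 3 gives > 20000 nM, which is a limit of the assay and not a number. The substituent on this nitrogen therefore does matter, although exchanging 3-aminopropyl for 4-aminocyclohexyl suggested otherwise, with a 1.2-fold higher number from compound 1 to compound 2 (0.08 log units; within the scatter): methyl gives an at least 3.3-fold higher number from compound 2 to compound 3 (0.52 log units; beyond the scatter), and the change from 3-aminopropyl to methyl gives an at least 4.0-fold higher number from compound 1 to compound 3 (0.60 log units; beyond the scatter). Among these compounds, the two groups carrying an amine stay level despite their different shapes, and only the small group without an amine falls beyond the scatter from both.

The change to methyl removes the amine and the carbon framework together, so a plain propyl or cyclohexyl group would be needed to separate the two. On these data alone, how far compound 3 really lies from the others also remains open, as its value is only a limit.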